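The source may hold more compounds than are shown below. What is called first, only, known or untested is meant among the compounds shown, and "the series" means these compounds.

Measured so far in a functional assay on BXPC-3 cells (Homo sapiens) for antiproliferative activity, read by MTT assay, with a stated time of 24 h (a higher number here means a weaker inhibitor, a lower number a stronger inhibitor), as follows
compound 1 (`CCn1c(C(=O)NCCN)ccc1C(CC)(CC)c1ccc(OCS(=O)(=O)c2ccccc2)c(C)c1`) gives 6430 nM
compound 2 (`CCn1c(C(=O)NC(C)(C)CO)ccc1C(CC)(CC)c1ccc(OCS(=O)(=O)c2ccccc2)c(C)c1`) gives 18300 nM
compound 3 (`CCn1c(C(=O)NC2(CO)CC2)ccc1C(CC)(CC)c1ccc(OCS(=O)(=O)c2ccccc2)c(C)c1`) gives 45400 nM

Compound 3 has the highest number of the three and is the weakest inhibitor here, with both of its gaps beyond the scatter. Compound 4 (`CCn1c(C(=O)N[C@H](CO)CCCO)ccc1C(CC)(CC)c1ccc(OCS(=O)(=O)c2ccccc2)c(C)c1`) has not yet been measured. For the measured compounds named here, the structural change from compound 3 is a group of 7 heavy atoms (5 carbon, 2 oxygen; no ring) in place of a group of 5 heavy atoms (4 carbon, 1 oxygen; one three-membered non-aromatic ring of carbon only), on an amide-type nitrogen and the incoming group has no measured precedent.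

Three measured steps at this nitrogen bear on the change, all modest and beyond the scatter (a 2.8-fold higher number from compound 1 to compound 2 (0.45 log units; beyond the scatter) and a 2.5-fold higher number from compound 2 to compound 3 (0.39 log units; beyond the scatter) and a 7.1-fold higher number from compound 1 to compound 3 (0.85 log units; beyond the scatter) in turn). Going by the values given here, the groups without a ring, in compound 1 (6430 nM) and compound 2 (18300 nM), both give lower numbers than the ring-bearing compound 3 and no measured compound goes against this, though three compounds are thin support.

In this assay a modest move to a lower number is therefore expected, similar in size to the gap between compound 2 and compound 3. The estimated step is a 2.3-fold lower number from compound 3 to compound 4 (0.36 log units; beyond the scatter) and it remains only an expectation. For compound 4 the estimate is 20000 nM with an expected range of 7000 nM to 50000 nM pending measurement.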

Compound 4, half-maximal inhibitory concentration: > 50000 nM
Compound 4: only a limit was reported; the forecaster's own chance of this, stated with the estimate: 10%; middle value at least 2.5-fold (0.39 log units) away from the limit.
By their numbers in this assay, from the lowest: compound 1; then compound 2; then compound 3. At a limit, above all of these: compound 4.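

Compound 4 stands at a limit and not at a number: the limit of > 50000 nM in this assay, at which 1 of the 4 values shown sits.

Lacking a ring does not by itself keep the number low at this amide-type nitrogen: the result gives an at least 2.7-fold higher number from compound 2 to compound 4 (0.43 log units; beyond the scatter) and an at least 7.7-fold higher number from compound 1 to compound 4 (0.89 log units; beyond the scatter), so compound 4 goes against the earlier reading that groups without a ring give lower numbers than the ring-bearing compound 3. Against that ring-bearing compound the result gives only an at least 1.1-fold higher number from compound 3 to compound 4 (0.04 log units; that floor lies within the scatter), so compound 4 cannot be placed in order relative to compound 3, while the 2-aminoethyl group of compound 1 stays clearly apart from all three groups carrying oxygen.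

The compounds shown leave open whether the lower number of compound 1 follows the amine itself, which a longer chain ending in an amine, or a chain of the same length ending in a carboxylic acid, would test. They also leave open how far past the limit compound 4 lies and whether the opposite configuration at its defined stereocentre would read differently.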